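Swapping the five-membered ring on the chlorophenyl arm

The source may hold more compounds than are shown below. What is called first, only, known or untested is meant among the compounds shown, and "the series" means these compounds.

Measured compounds:
compound 1 `Cn1nc2c(=O)n(CC3(O)CCN(Cc4ccc(-c5n[nH]c(=O)o5)cc4Cl)CC3)cnc2c1-c1ccc(CN)cc1` — 171 nM
compound 2 `Cn1nc2c(=O)n(CC3(O)CCN(Cc4ccc(-c5ccco5)cc4Cl)CC3)cnc2c1-c1ccc(CNCCO)cc1` — 8.2 nM
compound 3 `CN(C)Cc1ccc(-c2c3ncn(CC4(O)CCN(Cc5ccc(-c6ccco6)cc5Cl)CC4)c(=O)c3nn2C)cc1` — 131 nM

All three were tested in an assay on isolated protein for inhibition of ubiquitin carboxyl-terminal hydrolase 7 (Homo sapiens), with stated times of 30 min and 2 h; a lower number here means a stronger inhibitor, a higher number a weaker inhibitor. Compound 1 gives the highest number of the three; compound 3 lies within the scatter of it, while compound 2 sits well below. Among the measured compounds shown here, the only single-point step among the measured compounds, a 16-fold higher number from compound 2 to compound 3 (1.20 log units; beyond the scatter), concerns the amine on the other end of the molecule and is large.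

Compound 4 `Cn1nc2c(=O)n(CC3(O)CCN(Cc4ccc(-c5ncco5)cc4Cl)CC3)cnc2c1-c1ccc(CN)cc1` is compound 1 with one change: a group of 5 heavy atoms (3 carbon, 1 nitrogen, 1 oxygen; one five-membered aromatic ring with 2 hetero atoms) in place of a group of 6 heavy atoms (2 carbon, 2 nitrogen, 2 oxygen; one five-membered aromatic ring with 3 hetero atoms), on an aromatic carbon. For the measured compounds named here, no measured pair isolates a change of this five-membered ring. Going by the values given here, compounds 2 and 3 carry a furan at the same place but also differ from compound 1 elsewhere, so their values show only that a different five-membered ring there is compatible with strong or moderate inhibition. With nothing that bears directly on this change, the expectation for compound 4 is a number close to compound 1, with a modest step of a 1.6-fold lower number from compound 1 to compound 4 (0.19 log units; within the scatter) expected and wide uncertainty. Compound 4 is estimated at 110 nM in this assay, with a range from 30 nM to 400 nM.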

Compound 4, half-maximal inhibitory concentration: 1120 nM
Estimate against measurement, compound 4: 10-fold (1.01 log units) below; measured number outside the range, above it.
By their numbers in this assay, from the lowest: compound 2; then compounds 3 and 1 (each within the scatter of the next); then compound 4.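

In this assay, a 6.5-fold higher number from compound 1 to compound 4 (0.82 log units; beyond the scatter) shows that the five-membered ring on the chlorophenyl arm is not interchangeable, even though both groups are small, uncharged aromatic rings. Inhibition is weaker with 1,3-oxazol-2-yl, so the identity of this ring matters in its own right, separately from the amine at the other end of the molecule. The group that leaves has a hydrogen-bond donor and a double bond outside the ring, and the group that enters has neither, but this single step changes these features together, and no other data here explain the loss.

On these data alone, it remains open where a furan would fall on the core of compound 1, with its amine unchanged. As far as these compounds go, it is also open whether a thiophene or a carboxylic acid at this place would restore inhibition.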